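The compounds below may be only part of what the source reports. "The series", "measured", "known", "first", "only" and "open" are said of these compounds alone.

Working notes on a series built on the shared core of compound 3 `Nc1nc(-c2cccc(CO)c2)nc2sc(-c3ccco3)nc12`. In a functional assay on CHO cells for antagonist activity at adenosine receptor A2b (Homo sapiens), read by cAMP accumulation, with a stated time of 10 min (on this read-out lower numbers stand for stronger inhibition and higher numbers for weaker inhibition), compound 3 gives > 30000 nM, which is a limit of the assay and not a number. Compound 2 `Nc1nc(-c2ccccc2)nc2sc(-c3ccco3)nc12` stands at > 30000 nM, also a limit. Compound 1 `COc1cccc(-c2nc(N)c3nc(-c4ccccc4)sc3n2)c1` stands at > 30000 nM, again a limit. All three values sit at the limit of > 30000 nM in this assay, at which 3 of the 3 values shown sit, so the step that the two limits leave unreadable from compound 2 to compound 3 cannot be read in size or direction. The change to compound 4 `COc1cccc(-c2nc(N)c3nc(-c4ccco4)sc3n2)c1` is methoxy in place of hydroxymethyl on an aromatic carbon. For the measured compounds named here, no measured step bears on this change with a readable size, and the shared limit leaves no direction to follow. Potency is expected to stay at the same limit, making a step that the limit leaves unreadable from compound 3 to compound 4 the expected step. Compound 4 is therefore estimated at 40000 nM, with a range from 10000 nM to 150000 nM.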

Compound 4, half-maximal inhibitory concentration: > 30000 nM
Compound 4 ended at the assay's limit; the forecaster's own chance of this, stated with the estimate: 85%; the middle value does not contradict the limit.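

No step from compound 1, compound 2 or compound 3 to compound 4 can be read in size or direction, since all four compounds share one limit: the limit of > 30000 nM in this assay, at which 4 of the 4 values shown sit.

The compounds shown leave open which change to the shared core, if any, gives a readable value in this assay.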